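The compounds below may be only part of what the source reports. "The series", "measured", "known", "first", "only" and "open" are said of these compounds alone.

Working notes on the series. In an assay on L cells for inhibition of Protein-serine O-palmitoleoyltransferase porcupine (Mus musculus), read by reporter gene assay, with a stated time of 24 h (a lower number here means that less compound is needed, a higher number that more compound is needed for the effect), compound 2 `O=C(CNC(=O)c1nn(-c2ccc(F)cc2)c(=O)c2ccccc12)Nc1nc2ccc(C(F)(F)F)cc2s1` gives 90 nM, the highest of the two numbers in hand; the nearest is compound 1 `COc1ccc(-n2nc(C(=O)NCC(=O)Nc3nc4ccc(Cl)cc4s3)c3ccccc3c2=O)cc1`, which in this assay gives 15 nM, a difference beyond the scatter. Going by the values given here, compound 1 and compound 2 differ in two places, so no single step separates them. Compound 3 `O=C(CNC(=O)c1nn(-c2ccc(F)cc2)c(=O)c2ccccc12)Nc1nc2ccc(Cl)cc2s1` differs from compound 2 by chloro in place of trifluoromethyl on an aromatic carbon. Among the compounds with values here, with no measured step for this change, the expectation is a moderate decrease a 3.0-fold lower number from compound 2 to compound 3 (0.48 log units; beyond the scatter), because compound 1, which also carries chloro on that ring, gives 15 nM. Compound 3 is estimated at 30 nM, between 10 nM and 80 nM.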

Compound 3, half-maximal effective concentration: 25 nM
Compound 3: middle estimate off by 1.2-fold (0.08 log units), on the high side, within the range that was stated.
By their numbers in this assay, from the lowest: compounds 1 and 3 (each within the scatter of the next); then compound 2.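

In this assay, chloro in place of trifluoromethyl on this aromatic carbon gives a 3.6-fold lower number from compound 2 to compound 3 (0.56 log units; beyond the scatter), so this position responds to the change by more than the scatter. With chloro held, fluoro in place of methoxy on an aromatic carbon gives a 1.7-fold higher number from compound 1 to compound 3 (0.22 log units; within the scatter), a second place where the step stays within the scatter. Nothing on hand accounts for either step. The compounds shown compare only chloro and trifluoromethyl at the first place, leaving open how a nitrile or an amine would read there. Also open, on these data alone, is how a longer chain would read in place of fluoro or methoxy.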